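Bromo to methyl on the ketone-side ring of a chalcone

The compounds below may be only part of what the source reports. "The series", "measured", "known", "first", "only" and "open" are said of these compounds alone.

Measured compounds:
compound 1, `COc1cc(Br)cc(/C=C/C(=O)c2ccc(C)cc2)c1O`, 148%
compound 2, `O=C(/C=C/c1cc(Br)ccc1O)c1ccc(Br)cc1`, 47.6%

In an ADME assay on MCF-10A cells (Homo sapiens) for cytotoxicity, read by sulforhodamine B assay, with a stated time of 72 h, tested at 30 uM (a lower number here means a weaker effect, a higher number a stronger effect of the compound at the concentration tested), compound 1 gives 148%. In this assay compound 2 gives 47.6%, the lowest of the two numbers, and the gap to compound 1 lies well beyond the scatter. Among the measured compounds shown here, the two measured compounds differ in more than one place, so no single step between them can be read off.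

Compound 3, `Cc1ccc(C(=O)/C=C/c2cc(Br)ccc2O)cc1`, has not yet been tested in this assay. It differs from compound 2 in one place: methyl in place of bromo on an aromatic carbon. For the measured compounds named here, compound 1, the only other number, carries a methyl on the same ring and gives the higher value, but it also differs on the other ring, so its value is only a loose guide. Compound 3 is expected to move upward from compound 2 by a step of a number 32.4 percentage points higher from compound 2 to compound 3 (beyond the scatter), more likely beyond the scatter than within it, though a small change cannot be ruled out. Compound 3 is estimated at 80%, with a range from 40% to 130%.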

Compound 3, a percentage reported as activity, at one concentration (the size of the read-out at that concentration, not a potency): 49.4%
Compound 3: the middle estimate sits 30.6 percentage points above what was measured; the range from low to high includes it.
By their numbers in this assay, from the lowest: compounds 2 and 3 (each within the scatter of the next); then compound 1.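

In this assay, methyl in place of bromo on an aromatic carbon, para to a large group, gives a number 1.8 percentage points higher from compound 2 to compound 3 (within the scatter), so the read-out does not separate these two groups at this position in the shared core. Compound 3 also links the two earlier compounds to a single-place comparison: hydrogen in place of methoxy on an aromatic carbon of the other ring gives a number 98.6 percentage points lower from compound 1 to compound 3 (beyond the scatter), so between these two compounds the large step goes with that one change, while the swap of bromo for methyl shows no step beyond the scatter. No measurement shown here explains either step.

As far as these compounds go, it remains open whether other groups on the ketone-side ring, such as an amine or a carboxylic acid, would also leave the read-out in this assay within the scatter of compound 2. From the compounds shown here alone, it is equally open whether the large step seen with methoxy would recur with bromo in place of methyl on that ring, or with a longer chain such as ethoxy in place of methoxy.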